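Dichloroacetanilides: methoxy in place of nitro on the ring

The source may report more compounds than this note shows. Statements on the series, on what has been measured and on what is new or still open speak of the compounds shown alone.

Measured so far:
- compound 1 `Cc1cccc(NC(=O)C(Cl)Cl)c1`: "not determined" (no result reported) in a functional assay on Bel-7402 cells (Homo sapiens) for antiproliferative activity, read by MTT assay, with a stated time of 72 h; on this read-out higher numbers stand for weaker inhibition and lower numbers for stronger inhibition
- compound 2 `O=C(Nc1cccc([N+](=O)[O-])c1)C(Cl)Cl`: 15700 nM

Going by the values given here, compound 2 is the only member of the series with a number in this assay, so it stands alone and no comparison within the measured set is possible; compound 1 carries no result. Compound 3 `COc1cccc(NC(=O)C(Cl)Cl)c1` differs from compound 2 in one place: methoxy in place of nitro on an aromatic carbon, the group sitting on a six-membered aromatic ring of carbon only, meta to a group of 6 heavy atoms. Among the compounds with values here, no step between two measured compounds exists to calibrate this change, and nothing in the data says which direction it should take. The working expectation is that compound 3 stays close to compound 2, with the step from compound 2 to compound 3 estimated as a 1.3-fold higher number from compound 2 to compound 3 (0.11 log units; within the scatter), not clearly beyond the usual scatter. On that basis compound 3 is expected to give about 20000 nM in this assay, with a range from 6000 nM to 60000 nM, the wide span reflecting the absence of any comparable step in the series.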

Compound 3, half-maximal inhibitory concentration: 54800 nM
Compound 3: middle estimate off by 2.7-fold (0.44 log units), on the low side; measured number inside the range.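

Going by these compounds alone, the aromatic carbon that carries nitro in compound 2 responds to what sits on it: in this assay methoxy in place of nitro gives a 3.5-fold higher number from compound 2 to compound 3 (0.54 log units; beyond the scatter) and so provides the first calibrated step. Within this pair, the stronger inhibition lies with nitro rather than methoxy, although a single step fixes only the direction and size of this one exchange, not a trend for the position. The exchange changes more than one counted feature, since nitro leaves with 3 heavy atoms and 2 hydrogen-bond acceptors and methoxy enters with 2 heavy atoms and 1 hydrogen-bond acceptor, and no measurement available here connects any of these differences to the step.

Compound 1 stands at "not determined" (no result reported) and so adds no third point on this position, leaving the two values as the only reference for the series. Open questions are how an amine, a carboxylic acid or a longer chain such as ethoxy on the same aromatic carbon would compare with nitro and methoxy, and whether the step from nitro to methoxy would keep its direction with the dichloroacetyl part of the core changed.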